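Hexyl in Place of Phenyl on the Shared Core

A few compounds are considered here, and "the series" means these few. Any claim that something is new, unique, unknown or untested is made for them only; others in the source may bear on it.

Three compounds have been measured in a functional assay on PC-3 cells (Homo sapiens) for cytotoxicity, read by MTT assay, with a stated time of 72 h; a higher number here means a weaker inhibitor, a lower number a stronger inhibitor:

Compound 1, `COc1ccc2c(c1)[n+]([O-])nc(NCOCc1ccccc1)[n+]2[O-]` — compound 1 gives 8580 nM
Compound 2, `[O-][n+]1nc(NCOCc2ccccc2)[n+]([O-])c2ccccc21` — compound 2 gives 13400 nM
Compound 3, `CC(OCNc1n[n+]([O-])c2ccccc2[n+]1[O-])c1ccccc1` — compound 3 gives 6080 nM

Among these three numbers compound 2 holds the highest one. Its nearest neighbour is compound 1, and that step, a 1.6-fold higher number from compound 1 to compound 2 (0.19 log units; within the scatter), lies within the scatter. Its furthest neighbour is compound 3: a 2.2-fold lower number from compound 2 to compound 3 (0.34 log units; beyond the scatter), a modest step beyond the scatter.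

The unmeasured compound 4, `CCCCCCCOCNc1n[n+]([O-])c2ccccc2[n+]1[O-]`, is reached from compound 2 by one change: hexyl in place of phenyl on a saturated chain carbon bound to an oxygen on a saturated carbon. Neither measured step bears directly on this change. Among the compounds with values here, the step from compound 1 to compound 2 touches a methoxy group on the aromatic part of the core, and the step from compound 2 to compound 3 adds a methyl on the chain; both are small, and the replacement of a phenyl by a hexyl has no measured counterpart here. The account therefore expects no step beyond the scatter for compound 4 in this assay, with the estimated step being a 1.0-fold lower number from compound 2 to compound 4 (0.01 log units; within the scatter). Compound 4 is estimated at 13000 nM, with a range from 5000 nM to 35000 nM.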

Compound 4, half-maximal inhibitory concentration: 1210 nM
The estimate for compound 4 lay 11-fold (1.03 log units) above the measured number; the whole stated range lies above it.
By their numbers in this assay, from the lowest: compound 4; then compounds 3, 1 and 2 (each within the scatter of the next, the first and the last beyond it).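

Putting hexyl in place of phenyl on a saturated chain carbon bound to an oxygen on a saturated carbon gives an 11-fold lower number from compound 2 to compound 4 (1.04 log units; beyond the scatter) in this assay and is a far larger step than either the methoxy change on the core or the added methyl on the chain. Within the data shown here, this shows that the number at this place in the side chain can move much further than the earlier compounds indicated. It also shows that, for this pair, the aromatic ring is not needed for a lower number, as an open chain with no ring and the same count of heavy atoms gives the lower one. Nothing at hand accounts for the size of this step.

The compounds shown leave open whether the number depends on chain length, which a shorter butyl chain or a longer octyl chain would test, and whether a cyclohexyl ring at the same place would read like hexyl or like phenyl. They also leave open whether a methoxy on the core or a methyl on the chain would shift the number in the same way when combined with hexyl.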